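This account rests on a few compounds, and the source may have more. Where it says the series, first, only, none or still open, it means among the compounds named here.

Compound 1 `Cc1cc(CCC#N)cc(C)c1Oc1cc(Nc2ccc(C#N)cc2)c(N)cc1C(N)=O`: in an ADME assay on TZM cells (Homo sapiens) for cytotoxicity, read by XTT assay, with a stated time of 4 days (on this read-out higher numbers stand for lower toxicity in this test and lower numbers for higher toxicity in this test), compound 1 gives > 9400 nM, which is a limit of the assay rather than a number.
Compound 2 `Cc1cc(CCC#N)cc(C)c1Oc1cc(Nc2ccc(C#N)cc2)c(N)cc1N`: in this assay compound 2 gives > 25000 nM, also a limit of the assay.

Compound 2 therefore stands at the upper edge of what this assay can report; both values shown are limits, so neither compound showed a toxicity the test could put a number to. Among the measured compounds shown here, the single measured step, a step that the two limits leave unreadable from compound 1 to compound 2, cannot be sized, because its two ends sit at the limit of > 9400 nM in this assay, at which 1 of the 2 values shown sits, and (the limit of > 25000 nM in this assay, at which 1 of the 2 values shown sits).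

Compound 3 `CNC(=O)c1cc(N)c(Nc2ccc(C#N)cc2)cc1Oc1c(C)cc(CCC#N)cc1C` differs from compound 2 by methylcarbamoyl in place of amino on an aromatic carbon. For the measured compounds named here, the one measured step bears on it in reverse: a step that the two limits leave unreadable from compound 1 to compound 2 took carbamoyl away for amino, and compound 3 brings back a closely related group. With that step unreadable, no size beyond the scatter can be drawn from it, and the resemblance to compound 1 points to no measurable toxicity. Compound 3 is therefore expected to give 25000 nM, within 9400 nM to 100000 nM, most likely again only as a limit. The implied step a number no higher from compound 2 to compound 3 (the limit leaves the size open) is expected to be none beyond the scatter.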

Compound 3, half-maximal cytotoxic concentration: > 9100 nM
Compound 3 gave a limit, no number (the forecaster's own chance of this, stated with the estimate: 80%); the middle value lies beyond the limit too.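

Compound 3 gives > 9100 nM in this assay, again a limit of the assay and not a number. The steps joining compound 3 to compound 1 and to compound 2 therefore cannot be read. The compounds shown leave open whether amino, carbamoyl and methylcarbamoyl at this place differ in toxicity at all, and at what concentration any of the three would harm the cells.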